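Removing the methoxymethyl group from compound 2

This account rests on a few compounds, and the source may have more. Where it says the series, first, only, none or still open, it means among the compounds named here.

Compound 1 `C=C[C@@H]1C[C@@H](Cc2ccc(OC)c(O)c2)[C@H]2C(=O)C=CC(=C)[C@H]21`: 0.74 nM
Compound 2 `C=C1C=CC(=O)[C@@H]2[C@H](Cc3ccc(OCOC)c(F)c3)CC[C@H]12`: 77.4 nM

Both values come from a functional assay on HCT-116 cells (Homo sapiens) for antiproliferative activity, with a stated time of 72 h; on this read-out lower numbers stand for stronger inhibition and higher numbers for weaker inhibition. Compound 1 gives 0.74 nM and compound 2 stands highest of the two at 77.4 nM. The gap between the two lies beyond the scatter, and so compound 2 is the weaker inhibitor of the pair.

Compound 3 `C=C1C=CC(=O)[C@@H]2[C@H](Cc3ccc(O)c(F)c3)CC[C@H]12` arises from compound 2 by a single change: hydrogen in place of methoxymethyl on an oxygen on an aromatic ring. This places hydrogen in place of methoxymethyl on an oxygen on an aromatic ring, turning methoxymethoxy to hydroxy. Among the compounds with values here, no measured pair shows this change on its own, and compound 1 differs from compound 2 in more than one place. The size of the step can therefore be judged only loosely. Compound 1 carries a hydroxy on its aromatic ring and gives 0.74 nM. On that slim ground, a fall beyond the scatter is expected, towards stronger inhibition, though probably not to the level of compound 1. The expected change is a 7.7-fold lower number from compound 2 to compound 3 (0.89 log units; beyond the scatter). For compound 3 the estimated value is 10 nM, with an expected range from 2 nM to 50 nM.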

Compound 3, half-maximal inhibitory concentration: 126 nM
For compound 3 the middle estimate is 13-fold (1.10 log units) below the measured one, outside the stated range (above it).
By their numbers in this assay, from the lowest: compound 1; then compounds 2 and 3 (each within the scatter of the next).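

In this assay, putting hydrogen in place of methoxymethyl on an oxygen on an aromatic ring gives a 1.6-fold higher number from compound 2 to compound 3 (0.21 log units; within the scatter). Within the data shown here, this is the first direct reading of this change, and it shows that on the core shared by this pair, methoxymethoxy and hydroxy cannot be told apart at this position. A free hydroxy on the aromatic ring is therefore not enough on its own to bring a compound of this pair close to compound 1 at 0.74 nM, and the gap to that value has to lie in something other than this single change, as compound 1 differs from the pair in more than one place. What lies behind the result cannot be said, as nothing measured here speaks to a cause.

The compounds shown leave open whether a different group on this oxygen, such as an ethyl group or a longer chain carrying a carboxylic acid or an amine, would also read the same as hydroxy and methoxymethoxy. They also leave open which of the several differences between compound 1 and this pair accounts for the gap, and whether the same exchange of methoxymethyl for hydrogen would read alike on the core of compound 1.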